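A few compounds are considered here, and "the series" means these few. Any claim that something is new, unique, unknown or untested is made for them only; others in the source may bear on it.

Working notes on the series. For the measured compounds named here, in a functional assay on BMEC cells (Bos taurus) for antiproliferative activity (on this read-out lower numbers stand for stronger inhibition and higher numbers for weaker inhibition), compound 2 (`COc1cc(/C=C\Cc2cc(OC)c3ccoc3c2)cc(OC)c1OC`) gives 7500 nM, the lower of the two numbers so far, while compound 1 (`COc1cc(/C=C/Cc2cc(O)c3ccoc3c2)cc(OC)c1OC`) gives 27700 nM. Compound 3 (`COc1cc(/C=C/Cc2cc(OC)c3ccoc3c2)cc(OC)c1OC`) is still unmeasured: the two compounds have the same atoms and bonds and differ only in configuration as drawn: 1 of 1 stereo elements differ; a double bond is drawn Z in compound 2 and E in compound 3. The double bond is drawn Z in compound 2 and E in compound 3. Going by the values given here, no measured pair isolates this change, so the expectation is loose. It leans toward compound 1 at 27700 nM, which suggests weaker inhibition in this assay, beyond the scatter. The expected change is a 2.4-fold higher number from compound 2 to compound 3 (0.38 log units; beyond the scatter). The estimated value for compound 3 is 18000 nM, with an expected range of 6000 nM to 50000 nM.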

Compound 3, half-maximal inhibitory concentration: 75000 nM
For compound 3 the middle estimate is 4.2-fold (0.62 log units) below the measured one, outside the stated range (above it).
By their numbers in this assay, from the lowest: compound 2; then compound 1; then compound 3.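

The double bond geometry alone moves the number in this assay, with a 10-fold higher number from compound 2 to compound 3 (1.00 log units; beyond the scatter). The configuration is the only possible source of that step because nothing else separates the pair: the fact that compounds 2 and 3 differ only in the configuration as drawn
With the double bond drawn E, methyl in place of hydrogen on the aromatic oxygen gives a 2.7-fold higher number from compound 1 to compound 3 (0.43 log units; beyond the scatter), so the methyl does not lower the number in that pair.

As far as these compounds go, whether the methyl step holds with the double bond drawn Z remains open. So does the reading for an amine in place of that oxygen, or a longer chain on it.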